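This account rests on a few compounds, and the source may have more. Where it says the series, first, only, none or still open, it means among the compounds named here.

Measured compounds:
- compound 1 `O=c1c2cnn(-c3ccc(F)cc3)c2ncn1CC1(O)CCN(Cc2cccc(Cl)c2)CC1`: "not determined" (no result reported)
- compound 2 `O=c1c2cnn(-c3ccc(F)cc3)c2ncn1CC1(O)CCN(Cc2ccc(Cl)cc2)CC1`: 8000 nM
- compound 3 `COC(=O)c1ccccc1CN1CCC(O)(Cn2cnc3c(cnn3-c3ccc(F)cc3)c2=O)CC1`: "not determined" (no result reported)

The three compounds share one core and differ only in the group carried on the saturated chain carbon bound to the amine nitrogen of the ring. In an assay on Sf21 cells for inhibition of ubiquitin carboxyl-terminal hydrolase 7 (Homo sapiens), read by spectrophotometry, with stated times of 30 min and 2 h (on this read-out lower numbers stand for stronger inhibition and higher numbers for weaker inhibition), compound 2 gives 8000 nM. For compound 1 this assay has no result, and for compound 3 this assay has no result either, so compound 3 stands without a number of its own and without any neighbour that differs from it in just one place.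

Compound 4 `COC(=O)c1ccc(CN2CCC(O)(Cn3cnc4c(cnn4-c4ccc(F)cc4)c3=O)CC2)cc1` is the next step: 4-(methoxycarbonyl)phenyl in place of 2-(methoxycarbonyl)phenyl on a saturated chain carbon bound to an amine nitrogen in a ring. Among the measured compounds shown here, because no measured pair in this set shows what such a change does, the size and direction of the step cannot be read from the data; the only anchor is compound 2, whose group sits at the same ring position as the new group of compound 4.

On that anchor compound 4 is expected to give about 8000 nM in this assay, within a wide range from 2000 nM to 40000 nM.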

Compound 4, half-maximal inhibitory concentration: 4500 nM
Compound 4: middle estimate off by 1.8-fold (0.25 log units), on the high side, within the range that was stated.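

In this assay, putting methoxycarbonyl in place of chloro on an aromatic carbon gives a 1.8-fold lower number from compound 2 to compound 4 (0.25 log units; within the scatter). Among the compounds shown here, this is the first pair in the set with a number on both sides, and it shows that these two groups, which share little beyond their place on the ring, cannot be told apart in this read-out. No measurement at hand offers a reason for this result.

From the compounds shown here alone, with no result for compound 3, the step from it to compound 4 cannot be read, so how 2-(methoxycarbonyl)phenyl compares with 4-(methoxycarbonyl)phenyl stays open. Also open, going by these compounds, is whether a carboxylic acid or an amine in place of methoxycarbonyl on that aromatic carbon would give a step beyond the scatter.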